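Butyl in place of 2-methoxybenzyl: expectation for compound 4

The source may hold more compounds than are shown below. What is called first, only, known or untested is meant among the compounds shown, and "the series" means these compounds.

Compound 1 `CCOC(=O)c1ccc(-c2nn(Cc3ccccc3OC)c3ccccc23)cc1` is tested in a functional assay on cells (Platelet, Homo sapiens) for inhibition (a lower number here means a stronger inhibitor, a higher number a weaker inhibitor), where compound 1 gives > 10000 nM, a limit of the assay rather than a number. Compound 2 `CCOC(=O)c1cccc(-c2nn(Cc3ccccc3)c3ccccc23)c1` gives > 10000 nM, likewise a limit. Compound 3 `CCOC(=O)c1ccc(-c2nn(C(C)C)c3ccccc23)cc1` gives > 10000 nM, again a limit. Among the compounds with values here, all three values thus sit at the limit of > 10000 nM in this assay, at which 3 of the 3 values shown sit, and nothing so far resolves to a measured number.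

Compound 4 `CCCCn1nc(-c2ccc(C(=O)OCC)cc2)c2ccccc21` differs from compound 1 by propyl in place of 2-methoxyphenyl on a saturated chain carbon bound to an aromatic nitrogen. Within the data shown here, the only measured step that bears on this is a step that the two limits leave unreadable from compound 1 to compound 3, and its size cannot be read since both ends are limits. The change to compound 4, 2-methoxybenzyl to butyl, is of the same kind: a short alkyl chain entering where the 2-methoxyphenyl group left. With every value at the limit, no direction and no size beyond the scatter can be expected for a step that the limit leaves unreadable from compound 1 to compound 4, and a further limit is the most probable outcome. Compound 4 is estimated at 30000 nM, within 8000 nM to 200000 nM.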

Compound 4, half-maximal inhibitory concentration: > 10000 nM
Compound 4: only a limit was reported (the forecaster's own chance of this, stated with the estimate: 85%); the middle value does not contradict the limit.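

No step can be read from compound 1 to compound 4 or from compound 3 to compound 4, as both ends of each pair are limits: the limit of > 10000 nM in this assay, at which 4 of the 4 values shown sit.

The compounds shown leave open how butyl, isopropyl and 2-methoxybenzyl on the aromatic nitrogen compare in this assay, and what would bring a value inside its range.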